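Swapping Isopropyl for Phenyl in a Sulfonamide Series

The source may report more compounds than this note shows. Statements on the series, on what has been measured and on what is new or still open speak of the compounds shown alone.

Compound 1, `CC1CCN(C2CCN(S(=O)(=O)c3ccc(C(C)C)cc3)CC2)CC1`: in an ADME assay on HCT-116 cells (Homo sapiens) for cytotoxicity, read by CellTiter-Glo, with a stated time of 72 h (on this read-out lower numbers stand for stronger inhibition and higher numbers for weaker inhibition), compound 1 gives > 5000 nM, a limit of the assay.
Compound 2, `CC1CCN(C2CCN(S(=O)(=O)c3ccccc3-c3ccc(C(F)(F)F)cc3)CC2)CC1`: in this assay compound 2 gives > 5000 nM, also a limit.
Compound 3, `Cc1cc(C)c(S(=O)(=O)N2CCC(N3CCC(Cc4ccccc4)CC3)CC2)c(C)c1`: in this assay compound 3 gives > 5000 nM, also a limit.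

Compound 1 stands at the limit of > 5000 nM in this assay, at which 3 of the 3 values shown sit, so no number for it is known, only that its effect is too weak for the assay to resolve. Compounds 2 and 3 sit at that same limit. Compound 4, `CC1CCN(C2CCN(S(=O)(=O)c3ccc(-c4ccccc4)cc3)CC2)CC1`, differs from compound 1 in one place: phenyl in place of isopropyl on an aromatic carbon. Among the measured compounds shown here, no step between two measured compounds exists here to show how large such a change can be. In this assay compound 4 is therefore expected to remain weak, with an estimated step that the limit leaves unreadable from compound 1 to compound 4 of no size beyond the scatter. Compound 4 is estimated at 8000 nM, between 3000 nM and 30000 nM, most likely reported again only as a limit.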

Compound 4, half-maximal inhibitory concentration: > 5000 nM
Compound 4 ended at the assay's limit (the forecaster's own chance of this, stated with the estimate: 80%); the middle value does not contradict the limit.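

No step can be read from compound 1 to compound 4, since both values are limits and give no number to compare: the limit of > 5000 nM in this assay, at which 4 of the 4 values shown sit.

In this assay the compounds shown leave open whether phenyl and isopropyl differ in effect at all.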